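Trifluoromethyl in place of chloro on the shared core

A few compounds are considered here, and "the series" means these few. Any claim that something is new, unique, unknown or untested is made for them only; others in the source may bear on it.

In a functional assay on HL-60 cells (Homo sapiens) for antiproliferative activity, read by sulforhodamine B assay, with a stated time of 72 h (on this read-out lower numbers stand for stronger inhibition and higher numbers for weaker inhibition), compound 3 `S=C(N/N=C/c1ccc2ccccc2n1)Nc1ccc(Cl)cc1` gives > 100000 nM as a limit and not a number. Compound 1 `N#Cc1ccc(NC(=S)N/N=C/c2ccc3ccccc3n2)cc1` gives 4660 nM as a measured value. Compound 2 `Cc1ccc(NC(=S)N/N=C/c2ccc3ccccc3n2)cc1` gives 78300 nM as a measured value. Compound 4 `FC(F)(F)c1ccc(NC(=S)N/N=C/c2ccc3ccccc3n2)cc1` carries trifluoromethyl in place of chloro on an aromatic carbon. Replacing cyano with methyl gives a 17-fold higher number from compound 1 to compound 2 (1.23 log units; beyond the scatter) and replacing it with chloro gives an at least 21-fold higher number from compound 1 to compound 3 (1.33 log units; beyond the scatter) as large steps. Compound 4 also lacks cyano, so with an at least 1.2-fold higher number from compound 2 to compound 3 (0.10 log units; that floor lies within the scatter) as the nearest guide no step beyond the scatter is expected in this assay and any measured number should fall on the lower side. The expected change is an at least 1.6-fold lower number from compound 3 to compound 4 (0.22 log units; that floor lies within the scatter) and stays small. Compound 4 is estimated at 60000 nM with an expected range of 12000 nM to 100000 nM and may also return only a limit.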

Compound 4, half-maximal inhibitory concentration: 34900 nM
For compound 4 the middle estimate is 1.7-fold (0.24 log units) above the measured one, within the range that was stated.
By their numbers in this assay, from the lowest: compound 1; then compound 4; then compound 2. At a limit, above all of these: compound 3.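

In this assay, trifluoromethyl on this aromatic carbon separates from methyl (a 2.2-fold lower number from compound 2 to compound 4 (0.35 log units; beyond the scatter)), but cyano stays ahead of it (a 7.5-fold higher number from compound 1 to compound 4 (0.87 log units; beyond the scatter)). Against chloro, the change gives a floor and not a size (an at least 2.8-fold lower number from compound 3 to compound 4 (0.45 log units; beyond the scatter)). Compound 3 is held only as a limit: (the limit of > 100000 nM in this assay, at which 1 of the 4 values shown sits).

As far as these compounds go, whether an amine, a carboxylic acid or a methoxy group on this carbon would come closer to compound 1 than compound 4 does remains open. From the compounds shown here alone, the size of the chloro to trifluoromethyl step also remains open.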